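This account rests on a few compounds, and the source may have more. Where it says the series, first, only, none or still open, it means among the compounds named here.

Of the compounds shown here, two share a small two-ring core and have been tested in a functional assay on KB cells (Homo sapiens) for antiproliferative activity; on this read-out higher numbers stand for weaker inhibition and lower numbers for stronger inhibition. Compound 1, the bare core `Cc1nsc2[nH]cnc12`, gives 20000 nM in this assay. Compound 2, `Cc1nsc2[nH]c(SCc3ccccc3)nc12`, carries a benzylthio group on the core and gives 9000 nM in this assay. Among these two values compound 2 stands with the lower number, and its only neighbour, compound 1, sits at a higher number, a gap that lies beyond the usual scatter of repeated measurements.

Compound 3, `c1ccc(CSc2nc3cnsc3[nH]2)cc1`, is the next step from compound 2. The change is hydrogen in place of methyl on an aromatic carbon. The methyl that sat on an aromatic carbon of the five-membered aromatic ring is gone, and a hydrogen takes its place, so compound 3 keeps the benzylthio group of compound 2 on an otherwise trimmed core.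

Among the compounds with values here, no pair of measured compounds here differs only in such a methyl, so there is nothing to lean on directly. A small shift is expected, if any, most likely toward a somewhat higher number. The expected step from compound 2 to compound 3 in this assay is a 1.3-fold higher number from compound 2 to compound 3 (0.12 log units; within the scatter). For compound 3 the estimate in this assay is 12000 nM, within a range from 5000 nM to 30000 nM.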

Compound 3, half-maximal inhibitory concentration: 200 nM
The estimate for compound 3 lay 60-fold (1.78 log units) above the measured number; measured number outside the range, below it.
By their numbers in this assay, from the lowest: compound 3; then compound 2; then compound 1.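

In this assay, replacing the methyl with a hydrogen on an aromatic carbon of the five-membered aromatic ring gives a 45-fold lower number from compound 2 to compound 3 (1.65 log units; beyond the scatter), a large move for the loss of a single heavy atom. Within the data shown here, until now, the only contrast among the compounds was the benzylthio group on the shared core, whereas this result shows that the carbon next to the ring nitrogen, two ring bonds from the ring sulfur, can also strongly change the read-out, and that a methyl there goes with much weaker inhibition than a hydrogen. No measurement shown here explains why this small change has so large an effect.

The compounds shown leave open how other groups on this carbon would compare with hydrogen and methyl, for example an ethyl, a fluorine or an amine. From the compounds shown here alone, it also remains open whether a step of this size would appear with another group in place of the benzylthio group, such as a methylthio group or a longer phenethylthio chain.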